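The compounds below may be only part of what the source reports. "The series", "measured", "known", "first", "only" and "open" are said of these compounds alone.

Measured so far in an ADME assay on WI-38 cells (Homo sapiens) for cytotoxicity, read by MTT assay, with a stated time of 72 h; a higher number here means a weaker inhibitor, a lower number a stronger inhibitor:
compound 1, `CN(C)CCn1cnnc1-c1cc(Oc2ccc(NC(=O)Nc3ccc(F)c(F)c3)cc2F)ccn1`, gives > 50000 nM;
compound 2, `CN(C)CCn1cnnc1-c1cc(Oc2ccc(NC(=O)Nc3ccc(F)c(Cl)c3)cc2F)ccn1`, gives 7580 nM;
compound 3, `CN(C)CCCn1cnnc1-c1cc(Oc2ccc(NC(=O)Nc3ccc(F)c(F)c3)cc2F)ccn1`, gives 15300 nM.

The value for compound 1 is a limit of this assay, not a number. Compound 2 differs from compound 1 by chloro in place of fluoro on an aromatic carbon, and this gave an at least 6.5-fold lower number from compound 1 to compound 2 (0.81 log units; beyond the scatter); the step is open on one side because the limit of > 50000 nM in this assay, at which 1 of the 3 values shown sits, sits on compound 1. Compound 3 differs from compound 1 in its core by (dimethylamino)methyl in place of dimethylamino on a saturated chain carbon, two bonds along the chain from an aromatic nitrogen, giving an at least 3.2-fold lower number from compound 1 to compound 3 (0.51 log units; beyond the scatter).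

Compound 4, `CN(C)CCCn1cnnc1-c1cc(Oc2ccc(NC(=O)Nc3ccc(F)c(Cl)c3)cc2F)ccn1`, is not yet measured. It differs from compound 3 by chloro in place of fluoro on an aromatic carbon, the same change as from compound 1 to compound 2, at the same place. Resting on the step from compound 1 to compound 2, a lowering of similar size is expected, a 4.4-fold lower number from compound 3 to compound 4 (0.64 log units; beyond the scatter). Compound 4 is therefore estimated at 3500 nM, within 1200 nM to 10000 nM.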

Compound 4, half-maximal inhibitory concentration: 5370 nM
The estimate for compound 4 lay 1.5-fold (0.19 log units) below the measured number; the measured number falls inside the stated range.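

In this assay, among the compounds shown here, chloro in place of fluoro lowers the number on the core of compound 3 as well, a 2.8-fold lower number from compound 3 to compound 4 (0.45 log units; beyond the scatter), so the direction of this change carries over to a second core, though that rests on only two pairs of compounds. Whether its size carries over is not settled: the same change on two cores in this assay, an at least 6.5-fold lower number (0.81 log units; beyond the scatter) from compound 1 to compound 2 and a 2.8-fold lower number (0.45 log units; beyond the scatter) from compound 3 to compound 4; the limit leaves it open whether they differ Compound 1 gives > 50000 nM, which is a limit of the assay and not a number.

Going by these compounds, the chain change, (dimethylamino)methyl in place of dimethylamino, gives a 1.4-fold lower number from compound 2 to compound 4 (0.15 log units; within the scatter) when chloro is present, and its comparison between cores also stays open: the same change on two cores in this assay, an at least 3.2-fold lower number (0.51 log units; beyond the scatter) from compound 1 to compound 3 and a 1.4-fold lower number (0.15 log units; within the scatter) from compound 2 to compound 4; the limit leaves it open whether they differ How bromo at the same aromatic carbon, or a longer chain, would behave also remains open.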